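The source may hold more compounds than are shown below. What is called first, only, known or untested is meant among the compounds shown, and "the series" means these compounds.

Three compounds of one series have been examined in an ADME assay on L02 cells (Homo sapiens) for cytotoxicity, read by MTT assay, with a stated time of 24 h; a lower number here means a stronger inhibitor, a higher number a weaker inhibitor. Compound 1, `O=C1/C(=C/c2ccncc2)CN(S(=O)(=O)c2ccc(F)cc2)C/C1=C\c1ccccc1F`, gives 15600 nM. Compound 2, `O=C1/C(=C/c2ccncc2)CN(S(=O)(=O)c2ccc(Cl)cc2)C/C1=C\c1ccccc1F`, gives 15000 nM. Compound 3, `O=C1/C(=C/c2cccnc2)CN(S(=O)(=O)c2ccc(F)cc2)C/C1=C\c1ccccc1C(F)(F)F`, gives 16100 nM. Compound 2 arises from compound 1 by a single change, (chloro in place of fluoro on an aromatic carbon), and the result is a 1.0-fold lower number from compound 1 to compound 2 (0.02 log units; within the scatter). Compound 3 and compound 1 share much of their structure, but the difference between the two cores is not broken down here; their values in this assay lie within the scatter of each other, and no order between them can be read.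

Compound 4, `O=C1/C(=C/c2cccnc2)CN(S(=O)(=O)c2ccc(Cl)cc2)C/C1=C\c1ccccc1C(F)(F)F`, has not been measured in this assay. It arises from compound 3 by the same change that leads from compound 1 to compound 2, namely (chloro in place of fluoro on an aromatic carbon), and the place of the change is described in the same words in both cases. Among the four compounds this change occurs twice in all. Since that change left the value unmoved from compound 1 to compound 2, compound 4 is expected to give a number close to that of compound 3 in this assay, with an expected step of a 1.0-fold lower number from compound 3 to compound 4 (0.00 log units; within the scatter) resting on the measured step of a 1.0-fold lower number from compound 1 to compound 2 (0.02 log units; within the scatter). Compound 4 is therefore estimated at 16000 nM, with a likely range from 8000 nM to 32000 nM.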

Compound 4, half-maximal inhibitory concentration: 11900 nM
Beside the measured number, compound 4's estimate is 1.3-fold (0.13 log units) above it; low and high end bracket the measured number.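

In this assay, the change from (4-fluorophenyl)sulfonyl to (4-chlorophenyl)sulfonyl gives a 1.4-fold lower number from compound 3 to compound 4 (0.13 log units; within the scatter), and set beside the earlier case, the two steps do not differ: the same change on two cores in this assay, a 1.0-fold lower number (0.02 log units; within the scatter) from compound 1 to compound 2 and a 1.4-fold lower number (0.13 log units; within the scatter) from compound 3 to compound 4, 1.3-fold (0.11 log units) apart, within the scatter of two such steps. On these two cores the change therefore carries over in the limited sense that neither step moves the value beyond the scatter, so the earlier step was a fair guide to the new one. This does not show that the change has any real effect of its own on the value, and two cores cannot show that it would behave alike on other cores of the series, or that any small effect hidden within the scatter is the same on both.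

The compounds shown leave open whether a group other than fluoro or chloro at this place, such as a methoxy group, a nitrile, an amine or a carboxylic acid, would shift the value beyond the scatter. They also leave open what would happen if the sulfonyl link itself gave way to a carbonyl or an amide.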